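The source may hold more compounds than are shown below. What is called first, only, known or untested is meant among the compounds shown, and "the series" means these compounds.

Measured so far in a functional assay on A549 cells (Homo sapiens) for cytotoxicity, read by MTT assay, with a stated time of 72 h; on this read-out lower numbers stand for stronger inhibition and higher numbers for weaker inhibition:
- compound 1 `O=C(Nc1ccc(Oc2ccnc3[nH]ccc23)cc1)c1nn(-c2ccc(Br)cc2)ccc1=O`, 6240 nM
- compound 2 `Cc1cc(=O)n(-c2ccc(F)cc2)nc1C(=O)Nc1ccc(Oc2ncnc3[nH]ccc23)cc1`, reported only as the limit > 60000 nM
- compound 3 `Cc1cc(=O)n(-c2ccc(F)cc2)nc1C(=O)Nc1ccc(Oc2ncnc3[nH]ccc23)c(F)c1`, 42400 nM

Compound 3 stands highest of the two numbers in this assay; its nearest neighbour is compound 1, whose number is lower, and the remaining entry, compound 2, is a limit and not a number. Within the data shown here, the one single-place step among the measured compounds is an at least 1.4-fold lower number from compound 2 to compound 3 (0.15 log units; that floor lies within the scatter), and the limit of > 60000 nM in this assay, at which 1 of the 3 values shown sits, keeps the size of that step from being fixed.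

Compound 4 `Cc1cc(=O)n(-c2ccc(Br)cc2F)nc1C(=O)Nc1ccc(Oc2ncnc3[nH]ccc23)c(F)c1` is not yet measured. It differs from compound 3 by 4-bromo-2-fluorophenyl in place of 4-fluorophenyl on an aromatic nitrogen. Among the measured compounds shown here, no measured step touches this change: the step from compound 2 to compound 3 concerns a different ring, and compound 1, which also carries a bromine, differs from compound 3 in more than one place, so its lower number cannot be assigned to the bromine alone. With nothing bearing directly on the change, no step beyond the scatter is expected from compound 3 to compound 4. The expected step is a 1.7-fold lower number from compound 3 to compound 4 (0.23 log units; within the scatter), held loosely. Compound 4 is accordingly estimated near 25000 nM, between 8000 nM and 60000 nM.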

Compound 4, half-maximal inhibitory concentration: 6120 nM
Compound 4: the middle estimate sits 4.1-fold (0.61 log units) above what was measured; the measured number lies below the stated range.
By their numbers in this assay, from the lowest: compounds 4 and 1 (each within the scatter of the next); then compound 3. At a limit, above all of these: compound 2.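

In this assay the group on the aromatic nitrogen proves to be a place where the number can move, with a 6.9-fold lower number from compound 3 to compound 4 (0.84 log units; beyond the scatter) as the only step shown that is read as beyond the scatter. The change replaces 4-fluorophenyl with 4-bromo-2-fluorophenyl, bringing in the bromine and the added fluorine at once, so this single step cannot divide the gain between the two atoms. Nothing measured on these compounds gives a reason for the step.

Still open, going by these compounds, is how much of the step belongs to the bromine and how much to the added fluorine, and whether a chlorine, a methoxy group or a trifluoromethyl group in place of the bromine would keep it. Also open, on these data alone, is how far this aryl ring accepts a different kind of substituent, such as an amine or a carboxylic acid, and whether either would move the number in this assay further in the same direction or back towards that of compound 3.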